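Cytotoxicity of the benzoxazole sulfonamides; compound 4 pending

The source may hold more compounds than are shown below. What is called first, only, known or untested is meant among the compounds shown, and "the series" means these compounds.

Compound 1 `O=S(=O)(Nc1ccc(-c2nc3ccccc3o2)cc1)c1ccc(F)c(C(F)(F)F)c1` gives 82000 nM in an ADME assay on HEK293 cells (Homo sapiens) for cytotoxicity, read by resazurin assay, with a stated time of 48 h; on this read-out lower numbers stand for higher toxicity in this test and higher numbers for lower toxicity in this test. Compound 3 `O=S(=O)(Nc1ccc(-c2nc3ccccc3o2)cc1)c1cccc(C(F)(F)F)c1` reaches only the assay limit, > 100000 nM, in this assay. Compound 2 `Cc1cccc(S(=O)(=O)Nc2ccc(-c3nc4ccccc4o3)cc2)c1` likewise sits at the limit, > 100000 nM. The series therefore shows (the limit of > 100000 nM in this assay, at which 2 of the 3 values shown sit). The step from compound 1 to compound 3 is an at least 1.2-fold higher number from compound 1 to compound 3 (0.08 log units; that floor lies within the scatter), and the step from compound 2 to compound 3 is a step that the two limits leave unreadable from compound 2 to compound 3. Compound 4 `CS(=O)(=O)Nc1ccc(-c2nc3ccccc3o2)cc1` differs from compound 2 by methyl in place of 3-methylphenyl on a sulfonyl sulfur. Going by the values given here, neither measured step bears directly on this change, as both alter substituents on the 3-methylphenyl that leaves here; together they show only that no value falls into a toxic range. The step from compound 2 to compound 4 is expected to be a step that the limit leaves unreadable from compound 2 to compound 4, most likely another limit. Compound 4 is estimated at 110000 nM, within 45000 nM to 300000 nM.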

Compound 4, half-maximal cytotoxic concentration: > 100000 nM
Compound 4 gave a limit, no number (the forecaster's own chance of this, stated with the estimate: 70%); the middle value does not contradict the limit.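

Compound 4 gives only a limit, > 100000 nM, in this assay. Going by these compounds alone, compound 2 also stands at a limit, so no step between compound 2 and compound 4 can be read. As far as these compounds go, whether methyl in place of 3-methylphenyl changes the read-out at all stays open.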